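The source may report more compounds than this note shows. Statements on the series, on what has been measured and on what is new or still open speak of the compounds shown alone.

Working notes on the series. The shared core of compound 1 `Cc1ccc(C(=O)CSc2nc(O)c(C)c(Cc3cccc4ccccc34)n2)cc1` is carried unchanged into compound 2 `COC(=O)CSc1nc(O)c(C)c(Cc2cccc3ccccc23)n1` and compound 3 `CCOC(=O)CSc1nc(O)c(C)c(Cc2cccc3ccccc23)n1`; how compound 2 and compound 1 differ is counted as 4-methylphenyl in place of methoxy on a carbonyl carbon. Compound 4 `CCc1c(O)nc(SCC(=O)c2ccc(C)cc2)nc1Cc1cccc2ccccc12` has not been measured.

In a functional assay on MT4 cells (Homo sapiens) for cytotoxicity (a lower number here means that less compound is tolerated, a higher number that more compound is tolerated), compound 1 gives >= 251000 nM, which is a limit of the assay and not a number. Compound 2 gives >= 296000 nM in this assay, again a limit. Compound 3 gives >= 287000 nM in this assay, also a limit. Hence a step that the two limits leave unreadable from compound 1 to compound 2 and a step that the two limits leave unreadable from compound 1 to compound 3 cannot be sized. The change methyl in place of hydrogen on a saturated chain carbon bound to an oxygen next to a carbonyl group gives a step that the two limits leave unreadable from compound 2 to compound 3, and that step likewise stays unsized, since every value shown sits at a limit, as the limit of >= 251000 nM in this assay, at which 1 of the 3 values shown sits, the limit of >= 287000 nM in this assay, at which 1 of the 3 values shown sits, and the limit of >= 296000 nM in this assay, at which 1 of the 3 values shown sits, record.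

From compound 1 to compound 4 the change is methyl in place of hydrogen on a saturated chain carbon bound to an aromatic carbon. It is the same kind of change as from compound 2 to compound 3, not the same: there the place is on a saturated chain carbon bound to an oxygen next to a carbonyl group, here on a saturated chain carbon bound to an aromatic carbon. The step from compound 1 to compound 4 is expected to be a number no higher from compound 1 to compound 4 (the limit leaves the size open), set beside a step that the two limits leave unreadable from compound 2 to compound 3, and the expectation rests on compound 1, compound 2 and compound 3 all being reported only as limits in the limit of >= 251000 nM in this assay, at which 1 of the 3 values shown sits, the limit of >= 287000 nM in this assay, at which 1 of the 3 values shown sits, and (the limit of >= 296000 nM in this assay, at which 1 of the 3 values shown sits). Compound 4 is therefore expected in this assay at about 250000 nM, most likely again reported only as a limit, within 120000 nM to 400000 nM.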

Compound 4, half-maximal cytotoxic concentration: 6000 nM
Estimate against measurement, compound 4: 42-fold (1.62 log units) above; the whole stated range lies above it.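

Compound 1 stands in this assay only at a limit of the assay, not at a number: the limit of >= 251000 nM in this assay, at which 1 of the 4 values shown sits.

Methyl in place of hydrogen on a saturated chain carbon bound to an aromatic carbon gives an at least 41-fold lower number from compound 1 to compound 4 (1.62 log units; beyond the scatter), so on the core of compound 1 this one change means that far less compound is tolerated, a step beyond the scatter. This rests on a single pair and does not show that the change would act the same way on another core, since the steps among compound 1, compound 2 and compound 3 cannot be read, including the methyl for hydrogen step on a saturated chain carbon bound to an oxygen next to a carbonyl group, and the pair itself gives no reason for the drop.

The compounds shown leave open whether the same methyl to ethyl difference on the cores of compound 2 and compound 3 would also lower the number in this assay. They also leave open how a longer chain such as propyl at that place would read, and how a carboxylic acid or an amide would read in place of the ester of compound 2.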